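Phenyl in place of hydrogen on the ring nitrogen

The source may report more compounds than this note shows. Statements on the series, on what has been measured and on what is new or still open speak of the compounds shown alone.

Measured so far in a functional assay on A549 cells (Homo sapiens) for antiproliferative activity, read by MTT assay, with a stated time of 72 h (on this read-out lower numbers stand for stronger inhibition and higher numbers for weaker inhibition), on the shared core
Compound 1 `O=C1COc2ccc(-c3cnc(Cl)c(NS(=O)(=O)c4ccc(F)cc4)c3)cc2N1c1ccc(F)cc1` gives 22300 nM
Compound 2 `O=C1COc2ccc(-c3cnc(Cl)c(NS(=O)(=O)c4ccc(F)cc4)c3)cc2N1` gives > 40000 nM

Compound 2 is reported only as > 40000 nM in this assay and that is a limit, not a number. Compound 3 `O=C1COc2ccc(-c3cnc(Cl)c(NS(=O)(=O)c4ccc(F)cc4)c3)cc2N1c1ccccc1` differs from compound 2 by phenyl in place of hydrogen on an amide-type nitrogen in a ring. It carries phenyl in place of hydrogen on an amide-type nitrogen in a ring.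

Among the measured compounds shown here, one measured step bears on this change. It is an at least 1.7-fold higher number from compound 1 to compound 2 (0.25 log units; that floor lies within the scatter) with 4-fluorophenyl leaving the same nitrogen that takes up phenyl here. For the measured compounds named here, compound 1 at 22300 nM is the only number with a ring on that nitrogen, so it anchors the expectation. Read in reverse, that step points towards a lower number, but only modestly, and a result at the limit for compound 3 remains possible. The expected move is an at least 1.6-fold lower number from compound 2 to compound 3 (0.20 log units; that floor lies within the scatter) and it is estimated to be small. In this assay compound 3 is estimated at 25000 nM with an expected range from 12000 nM to 40000 nM as the working figure.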

Compound 3, half-maximal inhibitory concentration: 14700 nM
The estimate for compound 3 lay 1.7-fold (0.23 log units) above the measured number, within the range that was stated.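

In this assay, a ring on the amide-type nitrogen now has a readable link to a lower number, which the earlier step with 4-fluorophenyl at this nitrogen could not provide because its floor stayed within the scatter: an at least 2.7-fold lower number from compound 2 to compound 3 (0.43 log units; beyond the scatter). Fluoro on the aromatic carbon of that ring makes no difference that can be read, as the step between the two ring-bearing compounds stays within the scatter: a 1.5-fold lower number from compound 1 to compound 3 (0.18 log units; within the scatter). Compound 2 has only a limit and not a number, so the true size of the gain from phenyl remains unknown, and only its floor is established: the limit of > 40000 nM in this assay, at which 1 of the 3 values shown sits.

The compounds shown leave open whether the gain needs an aromatic ring on this nitrogen at all, or whether methyl, a longer chain such as n-butyl, or a saturated ring such as cyclohexyl would serve as well. On these data alone, it is also open whether a group on the phenyl ring other than fluoro, such as methoxy, an amine or a carboxylic acid, would move the number beyond the scatter from that of compound 3.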